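The source may report more compounds than this note shows. Statements on the series, on what has been measured and on what is new or still open speak of the compounds shown alone.

Measured in a functional assay on MCF7 cells (Homo sapiens) for antiproliferative activity, read by MTT assay, with a stated time of 72 h; on this read-out higher numbers stand for weaker inhibition and lower numbers for stronger inhibition:
- compound 1 `CCN1CCN(c2cc(C)c3cc(NC(=O)c4ccc(C)cc4)ccc3n2)CC1`: 6740 nM
- compound 2 `CCN1CCN(c2cc(C)c3cc(NC(=O)c4cccc(C)c4)ccc3n2)CC1`: 7800 nM
- compound 3 `CCc1ccccc1C(=O)Nc1ccc2nc(N3CCN(CC)CC3)cc(C)c2c1`: 15800 nM

Compound 3 has the highest number of the three. Both comparisons lie beyond the scatter, though only modestly: a 2.0-fold higher number from compound 2 to compound 3 (0.31 log units; beyond the scatter) and a 2.3-fold higher number from compound 1 to compound 3 (0.37 log units; beyond the scatter).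

The next compound, compound 4 `CCN1CCN(c2cc(C)c3cc(NC(=O)c4cccc(Br)c4)ccc3n2)CC1`, keeps the shared core and has 3-bromophenyl in place of 2-ethylphenyl on a carbonyl carbon.

Among the measured compounds shown here, no measured compound carries bromine, so the data show nothing directly about that group. The nearest guide is compound 2, whose 3-methylphenyl name matches the entering group most closely. Leaving 2-ethylphenyl was a modest step in both measured pairs, and a 1.2-fold higher number from compound 1 to compound 2 (0.06 log units; within the scatter) stays within the scatter. A modest step toward a lower number in this assay is therefore expected, close in size to the step between compound 2 and compound 3 but opposite in direction.

The expected change is a 2.0-fold lower number from compound 3 to compound 4 (0.31 log units; beyond the scatter).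

For compound 4 the estimated value is 7800 nM, with an expected range from 3500 nM to 16000 nM.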

Compound 4, half-maximal inhibitory concentration: 11600 nM
Beside the measured number, compound 4's estimate is 1.5-fold (0.17 log units) below it; measured number inside the range.
By their numbers in this assay, from the lowest: compounds 1, 2, 4 and 3 (each within the scatter of the next, the first and the last beyond it).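

In this assay, placing 3-bromophenyl on the carbonyl carbon in place of 2-ethylphenyl gives a 1.4-fold lower number from compound 3 to compound 4 (0.13 log units; within the scatter), so this change does not separate the two compounds, although compound 1 and compound 2 each stood apart from compound 3. Bromo in place of methyl on an aromatic carbon gives a 1.5-fold higher number from compound 2 to compound 4 (0.17 log units; within the scatter), and 3-bromophenyl in place of 4-methylphenyl gives a 1.7-fold higher number from compound 1 to compound 4 (0.24 log units; within the scatter), so compound 4 cannot be told apart from either compound. A bromine therefore enters this position without a step beyond the scatter from any of the three earlier compounds.

Going by these compounds, it remains open how a 3-chlorophenyl, a 3-methoxyphenyl or an aminophenyl group on the same carbonyl carbon would read in this assay. Nothing shown here explains the values of these compounds.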